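An open dihydroxypropyl chain in place of a ring

The source may report more compounds than this note shows. Statements on the series, on what has been measured and on what is new or still open speak of the compounds shown alone.

In a functional assay on A549 cells (Homo sapiens) for cytotoxicity, read by MTT assay, with a stated time of 72 h (on this read-out lower numbers stand for stronger inhibition and higher numbers for weaker inhibition), compound 1 `O=C1c2c[n+]([O-])c3ccccc3c2C(=O)c2c1c1ccccc1n2CCCCn1ccnc1` gives 170 nM, compound 2 `O=C1c2c[n+]([O-])c3ccccc3c2C(=O)c2c1c1ccccc1n2Cc1cn([C@@H]2C[C@H](O)[C@@H](CO)O2)nn1` gives 120 nM, and compound 3 `CC1(C)OCC(Cn2cc(Cn3c4c(c5ccccc53)C(=O)c3c[n+]([O-])c5ccccc5c3C4=O)nn2)O1` gives 80 nM. Compound 2 thus lies within the scatter of both other compounds. Compound 4 `O=C1c2c[n+]([O-])c3ccccc3c2C(=O)c2c1c1ccccc1n2Cc1cn(CC(O)CO)nn1` has 2,3-dihydroxypropyl in place of 4-hydroxy-5-(hydroxymethyl)oxolan-2-yl on an aromatic nitrogen. Among the measured compounds shown here, one measured step bears on this change. It replaces the same group with (2,2-dimethyl-1,3-dioxolan-4-yl)methyl, and it is a 1.5-fold lower number from compound 2 to compound 3 (0.18 log units; within the scatter). No step beyond the scatter is therefore expected in this assay, in either direction. The expected step is a 1.1-fold lower number from compound 2 to compound 4 (0.06 log units; within the scatter). Compound 4 is estimated at 105 nM, with an expected range of 45 nM to 240 nM.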

Compound 4, half-maximal inhibitory concentration: 880 nM
Estimate against measurement, compound 4: 8.4-fold (0.92 log units) below; the whole stated range lies below it.
By their numbers in this assay, from the lowest: compounds 3, 2 and 1 (each within the scatter of the next, the first and the last beyond it); then compound 4.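

In this assay, among the compounds shown here, this aromatic nitrogen proves sensitive to its substituent, which the earlier compounds did not show: the open 2,3-dihydroxypropyl chain gives a 7.3-fold higher number from compound 2 to compound 4 (0.87 log units; beyond the scatter) in place of the ring. The two ring-bearing groups thus stay within the scatter of each other, while the open chain also gives an 11-fold higher number from compound 3 to compound 4 (1.04 log units; beyond the scatter) and sits apart from the imidazolylpropyl compound with a 5.2-fold higher number from compound 1 to compound 4 (0.71 log units; beyond the scatter) on the same core. Nothing available explains this step.

The compounds shown leave open whether the open chain or its two hydroxyl groups matter here. A 3-hydroxypropyl chain or an aminopropyl chain on this nitrogen could separate the two.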